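The source may hold more compounds than are shown below. What is called first, only, known or untested is meant among the compounds shown, and "the series" means these compounds.

In a functional assay on A549 cells (Homo sapiens) for antiproliferative activity, read by CCK-8 assay, with a stated time of 72 h (a higher number here means a weaker inhibitor, a lower number a stronger inhibitor), compound 1 `Cc1cc(Nc2cc(N3CCN(C)CC3)nc(Nc3ccc([N+](=O)[O-])cc3)n2)n[nH]1` gives 723 nM. Among the compounds with values here, compound 2 `Cc1cc(Nc2cc(N3CCN(C)CC3)nc(Nc3cccc(Cl)c3)n2)n[nH]1` gives 723 nM, which leaves it level with compound 1 at the digits reported, and compound 1 is its only measured neighbour. Compound 3 `COc1ccc(Nc2nc(Nc3cc(C)[nH]n3)cc(N3CCN(C)CC3)n2)cc1` keeps the shared core and differs from compound 2 in one place: 4-methoxyphenyl in place of 3-chlorophenyl on a nitrogen on an aromatic ring. Put simply, 4-methoxyphenyl stands in place of 3-chlorophenyl on a nitrogen on an aromatic ring.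

Within the data shown here, only one measured step bears on this, and it falls at the same place, where 3-chlorophenyl replaced 4-nitrophenyl: no change at the digits printed from compound 1 to compound 2 (within the scatter). That single step suggests that this assay may not respond strongly to a swap of this group, so no shift in either direction beyond the scatter is expected. Among the measured compounds shown here, the evidence is thin, however, as no measured compound carries 4-methoxyphenyl, and the range is therefore kept wide. The expected step is a 1.0-fold higher number from compound 2 to compound 3 (0.02 log units; within the scatter). For compound 3 the estimated value is 750 nM, within an expected range of 300 nM to 1900 nM.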

Compound 3, half-maximal inhibitory concentration: 2650 nM
The estimate for compound 3 lay 3.5-fold (0.55 log units) below the measured number; the measured number lies above the stated range.
By their numbers in this assay, from the lowest: compounds 1 and 2 (each within the scatter of the next); then compound 3.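

In this assay, the position on the nitrogen on an aromatic ring turns out not to be indifferent to the group it carries, as the level pair of compound 1 and compound 2 had suggested: 4-methoxyphenyl in place of 3-chlorophenyl gives a 3.7-fold higher number from compound 2 to compound 3 (0.56 log units; beyond the scatter). Methoxy in place of nitro on an aromatic carbon points the same way, with a 3.7-fold higher number from compound 1 to compound 3 (0.56 log units; beyond the scatter), so among these three compounds the group 4-methoxyphenyl is the one that departs, while 3-chlorophenyl and 4-nitrophenyl stand level. Nothing available here offers an explanation for this weaker result with 4-methoxyphenyl.

The step from compound 2 to compound 3 changes both the group and where it sits on the phenyl ring, so these compounds leave open whether the shift follows the methoxy group itself or its placement, a question that 3-methoxyphenyl and 4-chlorophenyl would help to separate. They also leave open how this position would respond to an unsubstituted phenyl, or to a phenyl ring bearing a hydroxy group or an amine.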